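This account rests on a few compounds, and the source may have more. Where it says the series, first, only, none or still open, it means among the compounds named here.

Measured compounds:
Compound 1 `COc1ccc(C(=O)c2cc(OC)c(OC)c(OC)c2)cc1NC(=O)/C=C/c1cc(OC)c(OC)c(OC)c1` — in a functional assay on HT-29 cells (Homo sapiens) for cytotoxicity, read by MTT assay, with a stated time of 72 h (a lower number here means a stronger inhibitor, a higher number a weaker inhibitor), compound 1 gives 3100 nM.
Compound 2 `COc1cccc(/C=C/C(=O)Nc2cc(C(=O)c3cc(OC)c(OC)c(OC)c3)ccc2OC)c1` — compound 2 gives 1900 nM.
Compound 3 `COc1cc(C(=O)c2cc(OC)c(OC)c(OC)c2)cc(NC(=O)/C=C/c2cc(OC)c(OC)c(OC)c2)c1OC` — compound 3 gives 3100 nM.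

Compound 3 stands level with compound 1 at the digits shown, the two together at the high end of the three numbers, and its gap to compound 2 lies within the scatter, as no change at the digits printed from compound 1 to compound 3 (within the scatter) and a 1.6-fold lower number from compound 1 to compound 2 (0.21 log units; within the scatter) both show. Compound 4 `C#CCOc1cccc(/C=C/C(=O)Nc2cc(C(=O)c3cc(OC)c(OC)c(OC)c3)cc(OC)c2OC)c1` differs from compound 3 in one place: 3-(propargyloxy)phenyl in place of 3,4,5-trimethoxyphenyl on a double-bonded chain carbon bound to a double-bonded chain carbon. Among the measured compounds shown here, the one measured step that bears on this, a 1.6-fold lower number from compound 1 to compound 2 (0.21 log units; within the scatter), swapped the same trimethoxyphenyl for a smaller aryl group and stayed within the scatter. Compound 4 is therefore expected to move little, a 1.4-fold lower number from compound 3 to compound 4 (0.15 log units; within the scatter), giving an estimated 2200 nM with a range of 900 nM to 5500 nM.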

Compound 4, half-maximal inhibitory concentration: 8100 nM
Estimate against measurement, compound 4: 3.7-fold (0.57 log units) below; the whole stated range lies below it.
By their numbers in this assay, from the lowest: compounds 2, 1 and 3 (each within the scatter of the next); then compound 4.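

In this assay, this place on the double-bonded chain carbon proves sensitive to the choice of aryl group: a 2.6-fold higher number from compound 3 to compound 4 (0.42 log units; beyond the scatter) is a modest step, but it lies beyond the scatter, whereas a 1.6-fold lower number from compound 1 to compound 2 (0.21 log units; within the scatter) did not. Replacing 3,4,5-trimethoxyphenyl is therefore not neutral in every case. No measurement shown here accounts for this step. The compounds shown leave open whether the triple bond of the propargyloxy group matters, or only the presence of that group. A 3-ethoxyphenyl or 3-aminophenyl group at this place would bear on that question.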